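A few compounds are considered here, and "the series" means these few. Any claim that something is new, unique, unknown or untested is made for them only; others in the source may bear on it.

Values so far in a functional assay on HeLa cells (Homo sapiens) for cytotoxicity, read by MTT assay, with a stated time of 48 h (on this read-out lower numbers stand for stronger inhibition and higher numbers for weaker inhibition), are as follows.

compound 1 `C#CCNC(=O)Nc1cccc(CCl)c1` gives 1550 nM
compound 2 `C#CCNC(=O)Nc1cccc(COc2ccc(C(=O)OC)cc2)c1` gives 12300 nM
compound 3 `C#CCNC(=O)Nc1cccc(CNCc2ccccc2)c1` gives "not active" (no number reported)

Compound 3 has no single number on this read-out, so its place in the series is known only as a qualitative report. The two numbers available, with compound 2 reading higher than compound 1, come from compounds with other groups on the shared core. Neither isolates the change considered here.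

The next structure is compound 4 `C#CCNC(=O)Nc1cccc(CNCc2ccc(C)cc2)c1`. Its change is phenyl to 4-methylphenyl (methyl in place of hydrogen on an aromatic carbon), a methyl in place of hydrogen on an aromatic carbon.

Going by the values given here, no measured pair shows what this change does, so the step rests on expectation alone. With compound 3 reported as "not active" (no number reported) the expectation in this assay is no step beyond the scatter in either direction, and compound 4 may again return no number. If a number is reported, the estimated value for compound 4 is 25000 nM with an expected range from 6000 nM to 100000 nM on this read-out.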

Compound 4, half-maximal inhibitory concentration: 329000 nM
Compound 4: middle estimate off by 13-fold (1.12 log units), on the low side; measured number above the stated range.
By their numbers in this assay, from the lowest: compound 1; then compound 2; then compound 4.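

In this assay compound 4 gives 329000 nM while compound 3 has only a "not active" report, so no step can be read between compound 3 and compound 4. The compounds shown leave open what a methyl in place of hydrogen on the aromatic carbon does on this read-out. Nothing available bears on the cause of this result.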